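Same Atoms, Different Joining: Compound 2 to Compound 3

A few compounds are considered here, and "the series" means these few. Any claim that something is new, unique, unknown or untested is made for them only; others in the source may bear on it.

Compound 1 `COC(=O)N1CCN(C(=O)c2nc(Nc3cc(C4CC4)[nH]n3)c3cc(Cl)ccc3n2)C[C@H]1C`: 89.6%
Compound 2 `CC(OC(=O)C(C)C)OC(=O)N1CCN(C(=O)c2nc(Nc3cc(C4CC4)[nH]n3)c3cc(Cl)ccc3n2)C[C@H]1C`: 25.8%

For the measured compounds named here, in an assay for inhibition of serine/threonine-protein kinase PAK 4 (Homo sapiens), read by FRET and Z'-LYTE, with a stated time of 60 min, tested at 5 uM, in the presence of a further agent that is not named here (on this read-out higher numbers stand for a stronger effect at the one concentration tested and lower numbers for a weaker effect), compound 2 gives 25.8%, the lowest of the two measured numbers; compound 1 gives 89.6%, and the one measured step, a number 63.8 percentage points lower from compound 1 to compound 2 (beyond the scatter), separates them. Compound 3 `C[C@@H]1CN(C(=O)c2nc(Nc3cc(C4CC4)[nH]n3)c3cc(Cl)ccc3n2)CCN1C(=O)OCOC(=O)C(C)(C)C` differs from compound 2 by (((tert-butyl)carbonyl)oxy)methyl in place of 1-((isopropylcarbonyl)oxy)ethyl on an oxygen next to a carbonyl group. Going by the values given here, no measured step swaps one such group for another; the known step of a number 63.8 percentage points lower from compound 1 to compound 2 (beyond the scatter) concerns a different exchange and bears only loosely here. The step is therefore expected to stay within the scatter, a number 4.2 percentage points higher from compound 2 to compound 3 (within the scatter). For compound 3 the estimate in this assay is 30%, in a range from 10% to 60%.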

Compound 3, a percentage reported as inhibition, at one concentration (the size of the read-out at that concentration, not a potency): 24.1%
Estimate against measurement, compound 3: 5.9 percentage points above; low and high end bracket the measured number.
By their numbers in this assay, from the lowest: compounds 3 and 2 (each within the scatter of the next); then compound 1.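

Exchanging 1-((isopropylcarbonyl)oxy)ethyl for (((tert-butyl)carbonyl)oxy)methyl, two groups with the same atoms joined differently, stays within the scatter in this assay: a number 1.7 percentage points lower from compound 2 to compound 3 (within the scatter). The large drop seen with the first of these groups therefore also appears with the second, giving a number 65.5 percentage points lower from compound 1 to compound 3 (beyond the scatter). Nothing measured here gives a reason for this drop. On these data alone, whether an ethyl group or a longer unbranched chain on this oxygen would keep the number close to that of compound 1 remains open.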